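From bromo to chloro: compound 2 to compound 3

This account rests on a few compounds, and the source may have more. Where it says the series, first, only, none or still open, it means among the compounds named here.

Measured so far in a toxicity assay on THP-1 cells (Homo sapiens) for inhibition; on this read-out higher numbers stand for lower toxicity in this test and lower numbers for higher toxicity in this test:
- compound 1 `Cn1c(-c2ccccc2)cnc1NC(=O)c1ccccc1`: > 100000 nM
- compound 2 `Cn1c(-c2ccccc2)cnc1NC(=O)c1cccc(Br)c1`: > 50000 nM

Compound 2 gives > 50000 nM, which is a limit and not a number. For the measured compounds named here, the only other value, that of compound 1, is also a limit, so compound 2 cannot be ranked against it.

The next compound is compound 3 `Cn1c(-c2ccccc2)cnc1NC(=O)c1cccc(Cl)c1`, reached by chloro in place of bromo on an aromatic carbon, with chloro in place of bromo on an aromatic carbon. Going by the values given here, the one measured step that bears on this change is a step that the two limits leave unreadable from compound 1 to compound 2, bromo in place of hydrogen on an aromatic carbon. It gives no size to carry over, so no change beyond the scatter is expected in this assay, and another limit is the likeliest report. The expected step is a step that the limit leaves unreadable from compound 2 to compound 3. For compound 3 the estimated value is 75000 nM, with an expected range from 40000 nM to 150000 nM.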

Compound 3, half-maximal cytotoxic concentration: > 50000 nM
Compound 3 was reported as a limit; the forecaster's own chance of this, stated with the estimate: 85%; the middle value does not contradict the limit.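

In this assay compound 3 gives > 50000 nM, which is a limit and not a number. For the compounds shown here, no step among compound 1, compound 2 and compound 3 can be read. The compounds shown leave open whether any change at this place gives a measurable value in this assay.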